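This account rests on a few compounds, and the source may have more. Where it says the series, first, only, none or still open, it means among the compounds named here.

Compound 1, `Cc1nn(-c2ncnc3nc[nH]c23)c2c1C(OCc1ccc(C(C)C)cc1)CC(=O)N2`, gives 5 nM in a functional assay on HEK293 cells for agonist activity at G-protein coupled receptor 39 (Homo sapiens), read by scintillation proximity assay and inositol phosphate accumulation, with a stated time of 75 min, in the presence of a further agent that is not named here; on this read-out lower numbers stand for an effect already at smaller amounts and higher numbers for an effect only at larger amounts of compound.
Compound 2, `Cc1nn(-c2ncnc3nc[nH]c23)c2c1C(OCc1ccc(F)cc1)CC(=O)N2`, gives 1 nM in this assay.
Compound 3, `Cc1nn(-c2ncnc3nc[nH]c23)c2c1C(NC(=O)c1ccccc1)CC(=O)N2`, gives 3 nM in this assay.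

Among these three, compound 3 stands second highest in this assay; its gap to compound 1 lies within the scatter, while the step of a 3.0-fold higher number from compound 2 to compound 3 (0.48 log units; beyond the scatter) lies beyond it. The next compound, compound 4, `Cc1nn(-c2ncnc3nc[nH]c23)c2c1C(OCC(C)C)CC(=O)N2`, has not yet been measured. It differs from compound 3 as follows: isobutoxy in place of benzamido on a saturated ring carbon.

Among the measured compounds shown here, two measured steps bear on this change. The step of a 3.0-fold higher number from compound 2 to compound 3 (0.48 log units; beyond the scatter) shows that exchanging a benzyloxy-type ether for benzamido raised the number modestly, so the return to an ether in compound 4 might recover part of that. The step of a 5.0-fold lower number from compound 1 to compound 2 (0.70 log units; beyond the scatter), however, shows that what sits on the aromatic ring matters, and in compound 4 that ring is gone altogether. Weighing these, a modest rise in the number is expected for compound 4, as the step of a 3.3-fold higher number from compound 3 to compound 4 (0.52 log units; beyond the scatter). Compound 4 is thus estimated at 10 nM, in a range from 2 nM to 50 nM.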

Compound 4, half-maximal effective concentration: 4 nM
For compound 4 the middle estimate is 2.5-fold (0.40 log units) above the measured one, and the stated range covers the measured number.
By their numbers in this assay, from the lowest: compound 2; then compounds 3, 4 and 1 (each within the scatter of the next).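

The step of a 1.3-fold higher number from compound 3 to compound 4 (0.12 log units; within the scatter) shows that in this assay benzamido and isobutoxy on the saturated ring carbon cannot be told apart, so a number in this range does not depend on an aromatic ring in this group, nor on the hydrogen-bond donor of benzamido. Among the ethers, the outcome depends on which aromatic group is replaced: isopropyl in place of 4-isopropylphenyl gives a 1.3-fold lower number from compound 1 to compound 4 (0.10 log units; within the scatter), whereas isopropyl in place of 4-fluorophenyl gives a 4.0-fold higher number from compound 2 to compound 4 (0.60 log units; beyond the scatter), leaving compound 2 apart from the other ethers. No available evidence bears on what lies behind these results.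

The compounds shown leave open how an amine, a carboxylic acid or a longer chain would read on this saturated ring carbon. Also open, going by these compounds, is whether chloro on the aromatic ring would read like fluoro.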